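The source may hold more compounds than are shown below. What is called first, only, known or untested is meant among the compounds shown, and "the series" means these compounds.

Measured so far:
- compound 1, `O=S1(=O)CCC(CNCCCCN(C[C@H]2Cc3ccccc3CN2)[C@H]2CCCc3cccnc32)CC1`: 17 nM
- compound 2, `c1ccc2c(c1)CN[C@@H](CN(CCCCNC1CCSCC1)[C@H]1CCCc3cccnc31)C2`: 54.7 nM
- compound 3, `O=S1(=O)CCC(NCCCCN(C[C@H]2Cc3ccccc3CN2)[C@H]2CCCc3cccnc32)CC1`: 45.5 nM

In a functional assay on cells for antagonist activity at C-X-C chemokine receptor type 4 (Homo sapiens), read by fluorescence and calcium flux, with stated times of 25 min and 90 s (a higher number here means a weaker inhibitor, a lower number a stronger inhibitor), compound 3 stands second highest of the three numbers; the gap a 1.2-fold lower number from compound 2 to compound 3 (0.08 log units; within the scatter) lies within scatter, while a 2.7-fold higher number from compound 1 to compound 3 (0.43 log units; beyond the scatter) is beyond it. Compound 4, `CC(C)(CN)CCN(C[C@H]1Cc2ccccc2CN1)[C@H]1CCCc2cccnc21`, differs by a group of 5 heavy atoms (4 carbon, 1 nitrogen; no ring) in place of a group of 11 heavy atoms (7 carbon, 1 nitrogen, 2 oxygen, 1 sulfur; one six-membered non-aromatic ring with 1 hetero atom), on a saturated chain carbon, two bonds along the chain from an amine nitrogen. Among the compounds with values here, no measured step removes the ring at the chain end altogether; the nearest precedents, a 2.7-fold higher number from compound 1 to compound 3 (0.43 log units; beyond the scatter) and a 3.2-fold higher number from compound 1 to compound 2 (0.51 log units; beyond the scatter), show that trimming or altering that terminal group costs modestly. A larger loss of the terminal group is therefore expected to give a modest to moderate rise in this assay, a 2.9-fold higher number from compound 3 to compound 4 (0.46 log units; beyond the scatter). Compound 4 is estimated at 130 nM, range 40 nM to 420 nM.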

Compound 4, half-maximal inhibitory concentration: 69 nM
The estimate for compound 4 lay 1.9-fold (0.28 log units) above the measured number, within the range that was stated.
By their numbers in this assay, from the lowest: compound 1; then compounds 3, 2 and 4 (each within the scatter of the next).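

In this assay, the open-chain 1-(aminomethyl)-1-methylethyl group holds level with the ring-bearing ends, with a 1.5-fold higher number from compound 3 to compound 4 (0.18 log units; within the scatter) and a 1.3-fold higher number from compound 2 to compound 4 (0.10 log units; within the scatter), so at this position the six-membered non-aromatic ring is not needed to match compound 2 and compound 3. Only compound 1 stands apart, with a 4.1-fold higher number from compound 1 to compound 4 (0.61 log units; beyond the scatter). No evidence accompanies these results to explain them. Going by these compounds, whether the amine of the new group matters stays open, as a hydroxyl or a methyl in its place would test.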